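Adding a Nitro Group to an Anilino Side Chain

A few compounds are considered here, and "the series" means these few. Any claim that something is new, unique, unknown or untested is made for them only; others in the source may bear on it.

Measured compounds:
Compound 1 `CCOC(=O)C1=C(C)NC(=S)NC1c1cn(C(=O)CNc2ccccc2)c2ccccc12`: 450 ug/mL
Compound 2 `CCOC(=O)C1=C(C)NC(=O)NC1c1cn(C(=O)CNc2ccc([N+](=O)[O-])cc2Cl)c2ccccc12`: 5 ug/mL
Compound 3 `CCOC(=O)C1=C(C)NC(=O)NC1c1cn(C(=O)CNc2ccccc2[N+](=O)[O-])c2ccccc12`: 250 ug/mL

In a functional assay on HCT-116 cells (Homo sapiens) for cytotoxicity, read by MTT assay, with a stated time of 72 h (on this read-out lower numbers stand for stronger inhibition and higher numbers for weaker inhibition), compound 1 gives the highest of the three numbers. Compound 3 sits close to it, and the gap between the two is within the scatter, so no order between them can be claimed. Compound 2 lies far lower, beyond the scatter.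

Compound 4 `CCOC(=O)C1=C(C)NC(=S)NC1c1cn(C(=O)CNc2cccc([N+](=O)[O-])c2)c2ccccc12` differs from compound 1 in one place: nitro in place of hydrogen on an aromatic carbon. The nitro group enters on an aromatic carbon of a six-membered aromatic ring of carbon only, meta to a large group.

Within the data shown here, no measured step tests exactly this change. Among the measured compounds shown here, the only single step, a 50-fold higher number from compound 2 to compound 3 (1.70 log units; beyond the scatter), shows that moving a nitro group and removing a chlorine changes the number greatly, so a nitro group can matter in either direction. Compound 3 carries a nitro group and a different core and sits within the scatter of compound 1. Compound 4 is therefore expected to move no more than modestly, with a 2.3-fold lower number from compound 1 to compound 4 (0.35 log units; beyond the scatter). The estimate for compound 4 is 200 ug/mL, within 30 ug/mL to 500 ug/mL.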

Compound 4, half-maximal inhibitory concentration: 130 ug/mL
For compound 4 the middle estimate is 1.5-fold (0.19 log units) above the measured one, within the range that was stated.
By their numbers in this assay, from the lowest: compound 2; then compounds 4, 3 and 1 (each within the scatter of the next, the first and the last beyond it).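

Putting a nitro group in place of hydrogen on this aromatic carbon, meta to a large group, gives a 3.5-fold lower number from compound 1 to compound 4 (0.54 log units; beyond the scatter) in this assay. Since a lower number stands for stronger inhibition here, the change from phenyl to 3-nitrophenyl strengthens the effect modestly, and this is the first pair shown in which adding a nitro group is the only difference. Nothing measured here says why the number falls.

The compounds shown leave open whether an amine or a carboxylic acid on this same aromatic carbon would shift the number as nitro does, or whether a smaller group such as methoxy would do the same. They also leave open whether adding a nitro group at this place would give a similar step on the core of compound 3.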